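The source may report more compounds than this note shows. Statements on the series, on what has been measured and on what is new or still open speak of the compounds shown alone.

Measured so far:
compound 1, `O=S(=O)(c1ccc(Br)cc1)c1nc2ccccc2nc1N1CCCC1`, 37700 nM;
compound 2, `O=S(=O)(c1ccc(F)cc1)c1nc2ccccc2nc1N1CCCC1`, 20600 nM;
compound 3, `O=S(=O)(c1ccc(Br)cc1)c1nc2ccccc2nc1N1CCc2ccccc2C1`, a limit of > 50000 nM.

All three were tested in a functional assay on HCT-116 cells (Homo sapiens) for cytotoxicity, read by MTT assay, with a stated time of 72 h; a lower number here means a stronger inhibitor, a higher number a weaker inhibitor. Compound 1 gives 37700 nM in this assay. The change from compound 1 is fluoro in place of bromo on an aromatic carbon, and in this assay compound 2 gives 20600 nM, a step of a 1.8-fold lower number from compound 1 to compound 2 (0.26 log units; within the scatter). For compound 3 this assay reports only a limit, > 50000 nM, so that an at least 1.3-fold higher number from compound 1 to compound 3 (0.12 log units; that floor lies within the scatter) cannot be fixed more closely; the two cores differ by 1,2,3,4-tetrahydroisoquinolin-2-yl in place of pyrrolidin-1-yl on an aromatic carbon.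

Compound 4, `O=S(=O)(c1ccc(F)cc1)c1nc2ccccc2nc1N1CCc2ccccc2C1`, has not yet been measured in this assay. It differs from compound 3 by fluoro in place of bromo on an aromatic carbon, the same change as from compound 1 to compound 2, at the same place. Since that change gave a 1.8-fold lower number from compound 1 to compound 2 (0.26 log units; within the scatter), which lies within the scatter, and since compound 3 itself sits at the limit (the limit of > 50000 nM in this assay, at which 1 of the 3 values shown sits), compound 4 is expected to come out close to that limit, with an expected step of an at least 1.1-fold lower number from compound 3 to compound 4 (0.04 log units; that floor lies within the scatter). The estimate for compound 4 in this assay is 45000 nM, expected to lie between 18000 nM and 150000 nM.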

Compound 4, half-maximal inhibitory concentration: 16600 nM
For compound 4 the middle estimate is 2.7-fold (0.43 log units) above the measured one, outside the stated range (below it).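

In this assay, fluoro in place of bromo on the core carrying 1,2,3,4-tetrahydroisoquinolin-2-yl gives an at least 3.0-fold lower number from compound 3 to compound 4 (0.47 log units; beyond the scatter). This step lies beyond the scatter, whereas the same change on the core carrying pyrrolidin-1-yl stays within it, but that contrast does not show that the two cores respond differently to the change: the same change on two cores in this assay, a 1.8-fold lower number (0.26 log units; within the scatter) from compound 1 to compound 2 and an at least 3.0-fold lower number (0.47 log units; beyond the scatter) from compound 3 to compound 4; the limit leaves it open whether they differ With fluoro held constant, exchanging pyrrolidin-1-yl for 1,2,3,4-tetrahydroisoquinolin-2-yl gives a 1.2-fold lower number from compound 2 to compound 4 (0.09 log units; within the scatter), so this pair shows no measurable effect of the amine swap, and the comparison with the bromo pair remains unresolved: the same change on two cores in this assay, an at least 1.3-fold higher number (0.12 log units; that floor lies within the scatter) from compound 1 to compound 3 and a 1.2-fold lower number (0.09 log units; within the scatter) from compound 2 to compound 4; the limit leaves it open whether they differ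

The compounds shown leave open how a chloro, methoxy or nitrile group would read in place of the halogen on the phenyl ring. They also leave open whether a morpholine or a piperidine in place of the pyrrolidine would keep the values in this assay within the same range.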